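Replacing ethyl with methoxy: a half-life estimate for compound 3

The source may report more compounds than this note shows. Statements on the series, on what has been measured and on what is new or still open speak of the compounds shown alone.

Measured so far in an ADME assay on microsomes from liver (Rattus norvegicus) for metabolic stability; a higher number here means that the compound lasts longer, a lower number that the compound disappears faster
- compound 1 `CCS(=O)(=O)c1ccc(CNC(=O)c2ccc3c(c2)cc(Cc2ccccc2C(F)(F)F)n3C(C)C)cc1` gives 0.717 h
- compound 2 `CCc1ccccc1Cc1cc2cc(C(=O)NCc3ccc(S(=O)(=O)CC)cc3)ccc2n1C(C)C` gives 0.2 h

Of the two, compound 2 holds the lowest number (0.2 h) and compound 1 the higher one. The next compound, compound 3 `CCS(=O)(=O)c1ccc(CNC(=O)c2ccc3c(c2)cc(Cc2ccccc2OC)n3C(C)C)cc1` carries methoxy in place of ethyl on an aromatic carbon, ortho to a large group (methoxy in place of ethyl on an aromatic carbon). Among the compounds with values here, one measured step bears on this, an exchange on that same aromatic carbon (a 3.6-fold lower number from compound 1 to compound 2 (0.55 log units; beyond the scatter)) with ethyl in place of trifluoromethyl, modest but beyond the scatter. Within the data shown here, no methoxy compound has been measured, so that step shows only that this place can move the half-life, not which way methoxy will take it. With compound 2 at the bottom of the measured range (0.2 h) a small rise is expected. The expected step is smaller than the measured one (a 1.5-fold higher number from compound 2 to compound 3 (0.18 log units; within the scatter)). In this assay the expected value for compound 3 is 0.3 h (range 0.13 h to 0.7 h).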

Compound 3, half-life: 0.2 h
The estimate for compound 3 lay 1.5-fold (0.18 log units) above the measured number; the range from low to high includes it.
By their numbers in this assay, from the lowest: compounds 2 and 3 (each within the scatter of the next); then compound 1.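

In this assay the exchange of ethyl for methoxy on this aromatic carbon gives no change at the digits printed from compound 2 to compound 3 (within the scatter) and so leaves the half-life where it stood, which means that the 2-ethylbenzyl and 2-methoxybenzyl compounds cannot be told apart. The exchange of trifluoromethyl for methoxy gives a 3.6-fold lower number from compound 1 to compound 3 (0.55 log units; beyond the scatter) and matches the earlier exchange for ethyl, so among these three compounds only trifluoromethyl, in compound 1, stands apart at this place. Nothing shown gives a reason for either step.

On these data alone, whether a nitrile, a chlorine atom or a longer chain such as ethoxy at this place would read like compound 1 or like compound 2 and compound 3 remains open. As far as these compounds go, it is also open whether these exchanges would read the same with a different group elsewhere on the shared core.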